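This account rests on a few compounds, and the source may have more. Where it says the series, first, only, none or still open, it means among the compounds named here.

The shared core carries a side arm on a nitrogen on an aromatic ring, and the three measured compounds differ there. Compound 1 `CNc1nc(/C=C/c2cc(OC)c(OC)c(OC)c2)nc2ccsc12` bears a methyl; in a functional assay on L02 cells (Homo sapiens) for inhibition, read by Griess assay, with stated times of 1 h and 24 h (on this read-out lower numbers stand for stronger inhibition and higher numbers for weaker inhibition), compound 1 gives only a limit, > 1000000 nM. Compound 2 `COc1cc(/C=C/c2nc(Nc3ccc(C)cc3)c3sccc3n2)cc(OC)c1OC` bears a 4-methylphenyl; in this assay compound 2 also gives a limit, < 40000 nM. Compound 3 `COc1ccc(CNc2nc(/C=C/c3cc(OC)c(OC)c(OC)c3)nc3ccsc23)cc1` bears a 4-methoxybenzyl; in this assay compound 3 gives a limit, > 1000000 nM, which is the limit of > 1000000 nM in this assay, at which 2 of the 3 values shown sit. Among the steps, an at least 25-fold lower number from compound 1 to compound 2 (1.39 log units; beyond the scatter) and an at least 25-fold higher number from compound 2 to compound 3 (1.39 log units; beyond the scatter), while a step that the two limits leave unreadable from compound 1 to compound 3. Compound 4 `COc1cc(/C=C/c2nc(NCc3ccc(Cl)cc3)c3sccc3n2)cc(OC)c1OC` differs from compound 3 by chloro in place of methoxy on an aromatic carbon. Among the measured compounds shown here, no measured step changes only a group on that ring, so the expected step is a number no higher from compound 3 to compound 4 (the limit leaves the size open), none beyond the scatter. Compound 4 is therefore estimated at 1000000 nM, with a range from 300000 nM to 3000000 nM.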

Compound 4, half-maximal inhibitory concentration: > 1000000 nM
Compound 4: only a limit was reported; the forecaster's own chance of this, stated with the estimate: 75%; the middle value lies on the limit itself.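

With chloro in place of methoxy, compound 4 in this assay still gives only a limit, > 1000000 nM. The steps from compound 1 and from compound 3 to compound 4 cannot be read, so this swap shows no measurable change. What the new compound adds is that 4-chlorobenzyl, like 4-methoxybenzyl, stays clearly apart from the 4-methylphenyl arm, with an at least 25-fold higher number from compound 2 to compound 4 (1.39 log units; beyond the scatter). Still open, going by these compounds, is how chloro and methoxy truly compare, since neither compound gives a readable number. Also open, on these data alone, is whether an amine or a carboxylic acid at this place on the ring would give a readable number.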